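Trimming a methyl from the thioether side chain

The source may report more compounds than this note shows. Statements on the series, on what has been measured and on what is new or still open speak of the compounds shown alone.

Measured compounds:
- compound 1, `Cn1ncc2c(=O)n(-c3ccccc3)c(SC(C)(C)c3ccccc3)nc21`: 1390 nM
- compound 2, `CC(Sc1nc2nn(CC3COC3)cc2c(=O)n1-c1ccccc1)c1ccccc1`: 60 nM

Both compounds were tested in an assay on isolated protein for inhibition of Retinaldehyde dehydrogenase 3 (Homo sapiens); on this read-out lower numbers stand for stronger inhibition and higher numbers for weaker inhibition. Compound 1 gives 1390 nM, the higher of the two numbers and therefore the weaker inhibitor; compound 2 gives 60 nM, and the gap between the two lies beyond the usual scatter. Compound 3, `CC(Sc1nc2c(cnn2C)c(=O)n1-c1ccccc1)c1ccccc1`, has not yet been measured. It differs from compound 1 in one place: hydrogen in place of methyl on a saturated chain carbon bound to an aromatic carbon, a saturated chain carbon and a sulfur. Among the compounds with values here, no measured pair differs only in this way, so the size of the step cannot be read directly from the data. Compound 2 carries the same 1-phenylethyl group as compound 3 and gives the lower value, but differs from compound 3 elsewhere, so its number is only a hint. The step of a 9.3-fold lower number from compound 1 to compound 3 (0.97 log units; beyond the scatter) is expected to go toward stronger inhibition, beyond the scatter. Compound 3 is estimated at 150 nM, with a range from 40 nM to 600 nM.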

Compound 3, half-maximal inhibitory concentration: 73 nM
The estimate for compound 3 lay 2.1-fold (0.31 log units) above the measured number, and the stated range covers the measured number.
By their numbers in this assay, from the lowest: compounds 2 and 3 (each within the scatter of the next); then compound 1.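

Replacing one methyl with hydrogen turns 1-methyl-1-phenylethyl into 1-phenylethyl and gives a 19-fold lower number from compound 1 to compound 3 (1.28 log units; beyond the scatter) in this assay, a large gain in inhibition. Nothing else differs between these two compounds. The effect of this change can now be read directly rather than inferred from a compound that also differs elsewhere. At this saturated chain carbon bound to an aromatic carbon, a saturated chain carbon and a sulfur, a single methyl therefore separates a much weaker inhibitor from a much stronger one.

From the compounds shown here alone, it remains open whether an ethyl group, a hydroxyl group or a fluorine atom on this carbon would keep the lower number. The data shown offer no measurement that explains why this one methyl matters so much.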